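The compounds below may be only part of what the source reports. "The series", "measured", "known", "first", "only" and "open" are said of these compounds alone.

Series notes, continuing from compound 3.

Among the compounds with values here, the three measured members share one core and differ at a single aromatic position. Compound 1 `CC(C(=O)NCc1ccc(C(C)(C)C)nc1OC1CCCC1)c1ccc(NS(C)(=O)=O)c(F)c1` gives 1.5 nM in an assay on cells for antagonist activity at transient receptor potential cation channel subfamily V member 1 (Homo sapiens), read by FLIPR and calcium flux, with a stated time of 6 min; on this read-out lower numbers stand for stronger inhibition and higher numbers for weaker inhibition. Compound 2 `CC(C(=O)NCc1ccc(C(C)(C)C)nc1SCc1ccccc1)c1ccc(NS(C)(=O)=O)c(F)c1` gives 4 nM, and compound 3 `CCCOc1cc(C(C)(C)C)ccc1CNC(=O)C(C)c1ccc(NS(C)(=O)=O)c(F)c1` gives 4.4 nM. Compound 3 therefore carries the highest of the three numbers; its gap to compound 2 lies within the scatter, while its gap to compound 1 lies beyond it.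

The next member, compound 4 `CCCCSc1cc(C(C)(C)C)ccc1CNC(=O)C(C)c1ccc(NS(C)(=O)=O)c(F)c1`, remains to be measured. It differs from compound 3 in one place: butylsulfanyl in place of propoxy on an aromatic carbon. Within the data shown here, the only measured step that resembles this one is the change from compound 1 to compound 2, where benzylsulfanyl replaced cyclopentyloxy and gave a 2.7-fold higher number from compound 1 to compound 2 (0.43 log units; beyond the scatter). That swap, like the present one, exchanges an alkoxy group for an alkylsulfanyl group at the same kind of aromatic position, so a modest rise in the number is expected here as well, though the chain lengths differ and a single precedent supports it.

Compound 4 is therefore expected to give 10 nM in this assay, with a plausible range of 3.5 nM to 30 nM; this estimate corresponds to a 2.3-fold higher number from compound 3 to compound 4 (0.36 log units; beyond the scatter).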

Compound 4, inhibition constant: 6.7 nM
The estimate for compound 4 lay 1.5-fold (0.17 log units) above the measured number; low and high end bracket the measured number.
By their numbers in this assay, from the lowest: compound 1; then compounds 2, 3 and 4 (each within the scatter of the next).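

In this assay, the exchange at this place gives a 1.5-fold higher number from compound 3 to compound 4 (0.18 log units; within the scatter), so on the shared core of compound 3 a butylsulfanyl group, ortho to a large group and meta to a tert-butyl group, reads the same as propoxy within the usual scatter. Within the data shown here, the only earlier exchange of an oxygen-linked group for a sulfur-linked one, benzylsulfanyl in place of cyclopentyloxy, gave a 2.7-fold higher number from compound 1 to compound 2 (0.43 log units; beyond the scatter), so a step beyond the scatter does not carry over to this pair, and a change of linking atom does not by itself shift the number across these two steps. No data on hand offer any explanation for this difference between the two steps.

The step from compound 3 to compound 4 alters the linking atom and the chain together, so the contribution of each stays unresolved; a butoxy or a propylsulfanyl group at the same place would separate them. Also open, on these data alone, is how this place responds to a group of another kind, such as a butylamino group, a carboxylic acid or a longer chain such as hexylsulfanyl.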